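The source may report more compounds than this note shows. Statements on the series, on what has been measured and on what is new or still open speak of the compounds shown alone.

Measured so far in an assay on Cerebral cortex for binding affinity to adenosine receptor A1 (Cavia porcellus), read by radioligand binding; a higher number here means a weaker inhibitor, a lower number a stronger inhibitor:
- compound 1 `C=CCn1c(=O)c2[nH]cnc2n(CCC)c1=O`: 1700 nM
- compound 2 `CCCn1c(=O)n(CCC(=O)O)c(=O)c2[nH]cnc21`: only a limit of the assay, > 200000 nM
- compound 3 `CCCn1c(=O)n(CCO)c(=O)c2[nH]cnc21`: 50000 nM

Compound 3 stands highest of the two numbers; its nearest neighbour is compound 1, with a 29-fold higher number from compound 1 to compound 3 (1.47 log units; beyond the scatter). Compound 4 `CCCn1c(=O)n(CCCOC)c(=O)c2[nH]cnc21` is the next step: methoxymethyl in place of hydroxy on a saturated chain carbon, two bonds along the chain from an aromatic nitrogen. Going by the values given here, two measured steps bear on it. At the same place, an at least 4.0-fold lower number from compound 2 to compound 3 (0.60 log units; beyond the scatter); one bond further in, a 29-fold higher number from compound 1 to compound 3 (1.47 log units; beyond the scatter). Both changes at this position moved the number by a large margin, so a step beyond the scatter is plausible, but neither fixes the direction for a methoxymethyl group. The expectation for compound 4 is therefore a modest step, a 1.7-fold lower number from compound 3 to compound 4 (0.22 log units; within the scatter), with wide uncertainty; compound 4 is estimated at 30000 nM (range 7000 nM to 150000 nM) in this assay.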

Compound 4, inhibition constant: 12400 nM
Compound 4: the middle estimate sits 2.4-fold (0.38 log units) above what was measured; measured number inside the range.
By their numbers in this assay, from the lowest: compound 1; then compound 4; then compound 3. At a limit, above all of these: compound 2.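

In this assay, the chain end at this position can also lower the number: methoxymethyl in place of hydroxy gives a 4.0-fold lower number from compound 3 to compound 4 (0.61 log units; beyond the scatter). This does not reach the level of the shorter unsaturated chain, since 2-methoxyethyl in place of vinyl gives a 7.3-fold higher number from compound 1 to compound 4 (0.86 log units; beyond the scatter). Methoxymethyl in place of carboxy gives an at least 16-fold lower number from compound 2 to compound 4 (1.20 log units; beyond the scatter), read from a value that is only a limit: the limit of > 200000 nM in this assay, at which 1 of the 4 values shown sits.

On these data alone, whether the gain follows the longer chain or the capped oxygen stays open, as 2-hydroxyethyl to 3-methoxypropyl changes both. A 3-hydroxypropyl chain or an amine at the chain end would help separate these.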